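Compound 3 to compound 4: swapping the amide tail

The source may report more compounds than this note shows. Statements on the series, on what has been measured and on what is new or still open speak of the compounds shown alone.

Measured in a functional assay on HCT-116 cells (Homo sapiens) for cytotoxicity; a higher number here means a weaker inhibitor, a lower number a stronger inhibitor:
Compound 1 `COc1cc(N2CCN(C(=O)N3CCN(C)CC3)CC2)ccc1Nc1nc(NC2CCCCC2)c2nc[nH]c2n1` gives 17 nM
Compound 2 `COc1cc(N2CCN(Cc3ccccn3)CC2)ccc1Nc1nc(NC2CCCCC2)c2nc[nH]c2n1` gives 51 nM
Compound 3 `COc1cc(N2CCC(C(=O)N3CCOCC3)CC2)ccc1Nc1nc(NC2CCCCC2)c2nc[nH]c2n1` gives 50 nM

Compound 3, at 50 nM, cannot be told apart from compound 2, at 51 nM. Only compound 1 shows a clearly lower number. The next structure is compound 4 `COc1cc(N2CCC(CC(=O)N3CCC(N(C)C)C3)CC2)ccc1Nc1nc(NC2CCCCC2)c2nc[nH]c2n1`, and the change is ((3-(dimethylamino)pyrrolidin-1-yl)carbonyl)methyl in place of (morpholin-4-yl)carbonyl on a saturated ring carbon. In words, ((3-(dimethylamino)pyrrolidin-1-yl)carbonyl)methyl stands in place of (morpholin-4-yl)carbonyl on a saturated ring carbon.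

Within the data shown here, no measured step makes this change at this place. Among the measured compounds shown here, the only measured step is a 3.0-fold higher number from compound 1 to compound 2 (0.48 log units; beyond the scatter), a modest one at a different place, so it bears on the size of the expected step only loosely. It does show that the number in this series moves little with a large group swap. Compound 1, at 17 nM, carries (4-methylpiperazin-1-yl)carbonyl, so a slight lean to a lower number is expected, though this is weak evidence. The expected step is a 1.4-fold lower number from compound 3 to compound 4 (0.15 log units; within the scatter). For compound 4 the estimated value is 35 nM, with an expected range of 12 nM to 100 nM.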

Compound 4, half-maximal inhibitory concentration: 59 nM
Compound 4: the middle estimate sits 1.7-fold (0.23 log units) below what was measured, within the range that was stated.
By their numbers in this assay, from the lowest: compound 1; then compounds 3, 2 and 4 (each within the scatter of the next).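

In this assay, replacing (morpholin-4-yl)carbonyl with ((3-(dimethylamino)pyrrolidin-1-yl)carbonyl)methyl on a saturated ring carbon gives a 1.2-fold higher number from compound 3 to compound 4 (0.07 log units; within the scatter). Among these compounds, this is the first step read at this place, and it shows that a tail with 11 heavy atoms and a five-membered ring can stand in place of one with 8 heavy atoms and a six-membered ring with no change beyond the scatter. The data offer no measured property that bears on this result.

As far as these compounds go, the step alters the amine ring and the added methyl link together, so the contribution of each part remains open. Also open, from the compounds shown here alone, is how a carboxylic acid or a longer chain on this ring carbon would read in this assay.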